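The source may report more compounds than this note shows. Statements on the series, on what has been measured and on what is new or still open speak of the compounds shown alone.

Among the compounds with values here, in an ADME assay on HEK-293T cells (Homo sapiens) for cytotoxicity, read by MTT assay, with a stated time of 24 h (a lower number here means that less compound is tolerated, a higher number that more compound is tolerated), three compounds built on a shared core have numbers so far. Compound 1 `Cc1ccc(-c2nn(-c3ccccc3)cc2-c2nc3ccccc3[nH]2)cc1`, with hydrogen on an aromatic nitrogen, gives 187000 nM. Compound 2 `Cc1ccc(-c2nn(-c3ccccc3)cc2-c2nc3ccccc3n2S(=O)(=O)c2ccccc2)cc1`, with phenylsulfonyl on that nitrogen, gives 138000 nM. Compound 3 `Cc1ccc(-c2nn(-c3ccccc3)cc2-c2nc3ccccc3n2S(=O)(=O)c2ccc(C)cc2)cc1`, with (4-methylphenyl)sulfonyl there, gives 79300 nM. Compound 2 stands close to both others, as the data show a 1.4-fold lower number from compound 1 to compound 2 (0.13 log units; within the scatter) and a 1.7-fold lower number from compound 2 to compound 3 (0.24 log units; within the scatter). Only the outer pair is separated, with a 2.4-fold lower number from compound 1 to compound 3 (0.37 log units; beyond the scatter), and that modest step includes the addition of the whole sulfonyl group.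

Compound 4 `Cc1ccc(-c2nn(-c3ccccc3)cc2-c2nc3ccccc3n2S(=O)(=O)c2ccc(Cl)cc2)cc1` differs from compound 2 in one place: chloro in place of hydrogen on an aromatic carbon. The closest measured change is the methyl in place of hydrogen on an aromatic carbon that leads to compound 3, a step that stayed within the scatter. Within the data shown here, no chloro compound has a number yet, so this is only a guide. A small drop that stays within the scatter is therefore expected, and the estimated change is a 1.5-fold lower number from compound 2 to compound 4 (0.16 log units; within the scatter). For compound 4 the estimated value is 95000 nM, with an expected range of 50000 nM to 170000 nM.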

Compound 4, half-maximal cytotoxic concentration: 167000 nM
Beside the measured number, compound 4's estimate is 1.8-fold (0.24 log units) below it, and the stated range covers the measured number.
By their numbers in this assay, from the lowest: compounds 3, 2, 4 and 1 (each within the scatter of the next, the first and the last beyond it).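

Chloro on this aromatic carbon, para to a large group, gives a 1.2-fold higher number from compound 2 to compound 4 (0.08 log units; within the scatter) and so cannot be told apart from hydrogen there. Set against methyl at the same place, it gives a 2.1-fold higher number from compound 3 to compound 4 (0.32 log units; beyond the scatter) and this is the first comparison at this carbon to fall beyond the scatter, though only modestly. Replacing the hydrogen on the aromatic nitrogen with (4-chlorophenyl)sulfonyl gives a 1.1-fold lower number from compound 1 to compound 4 (0.05 log units; within the scatter) so among these sulfonyl compounds only compound 3 stands apart from compound 1.

Nothing available here explains why chloro and methyl differ at this place. As far as these compounds go, it remains open whether fluoro, methoxy, an amine or a carboxylic acid at this same carbon would group with hydrogen and chloro or with methyl.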